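Swapping Cyclopentyl for Difluorophenyl on an Amide

The source may hold more compounds than are shown below. What is called first, only, known or untested is meant among the compounds shown, and "the series" means these compounds.

Compound 1 `O=C(C1CCC1)N1CCC[C@H]1c1nc(-c2cccc(F)c2)no1` and compound 2 `O=C(C1CCCC1)N1CCCC1c1nc(-c2cccc(F)c2)no1` share one core and differ only in the group on the carbonyl carbon. In an in vitro functional assay on HEK293-A cells for positive allosteric modulation of metabotropic glutamate receptor 5 (Homo sapiens), read by fluorescence and calcium flux, with a stated time of 140 s (a higher number here means that more compound is needed for the effect, a lower number that less compound is needed), compound 1 gives 7000 nM, while compound 2 gives 1000 nM, the lowest of the two numbers and a gap beyond the usual scatter. Compound 3 `O=C(c1ccc(F)cc1F)N1CCCC1c1nc(-c2cccc(F)c2)no1` follows from compound 2 by 2,4-difluorophenyl in place of cyclopentyl on a carbonyl carbon. Among the measured compounds shown here, no measured pair shows a change of this kind, so the expected step of a 1.4-fold lower number from compound 2 to compound 3 (0.15 log units; within the scatter) is small, probably within the scatter and, if anything, toward a lower number. Compound 3 is therefore estimated at 700 nM, with a range from 150 nM to 4000 nM.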

Compound 3, half-maximal effective concentration: 10000 nM
Compound 3: middle estimate off by 14-fold (1.15 log units), on the low side; measured number above the stated range.
By their numbers in this assay, from the lowest: compound 2; then compounds 1 and 3 (each within the scatter of the next).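

At this carbonyl carbon the group is not interchangeable: 2,4-difluorophenyl in place of cyclopentyl gives a 10-fold higher number from compound 2 to compound 3 (1.00 log units; beyond the scatter) in this assay, so far more compound is needed for the effect. Of these two groups, cyclopentyl is clearly the better one at this position. Nothing in the available data explains why the step is this large.

Still open, from the compounds shown here alone, is whether the higher number goes with the aromatic ring itself or with its two fluorine atoms. A plain phenyl group on the same carbonyl carbon would help separate the two.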